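Three Esters Measured, a Fourth Ester Awaiting Its Number

The compounds below may be only part of what the source reports. "The series", "measured", "known", "first", "only" and "open" are said of these compounds alone.

All three measured compounds were tested in a functional assay on SK-BR-3 cells (Homo sapiens) for antiproliferative activity, read by MTT assay, with a stated time of 72 h; on this read-out lower numbers stand for stronger inhibition and higher numbers for weaker inhibition:

Compound 1 `C/C=C1/[C@H](O[C@@H]2O[C@H](COC(C)=O)[C@@H](OC(C)=O)[C@H](OC(C)=O)[C@H]2OC(C)=O)OC=C(C(=O)OC)[C@H]1CC(=O)OCCC` gives 6600 nM in this assay.
Compound 2 `C/C=C1/[C@H](O[C@@H]2O[C@H](CO)[C@@H](O)[C@H](O)[C@H]2O)OC=C(C(=O)OC)[C@H]1CC(=O)OCCc1ccc(OC)c(OC)c1` gives only a limit of the assay in this assay, > 15000 nM.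
Compound 3 `C/C=C1/[C@H](O[C@@H]2O[C@H](CO)[C@@H](O)[C@H](O)[C@H]2O)OC=C(C(=O)OC)[C@H]1CC(=O)OCCCCCCCCCCCCCCC` gives 1600 nM in this assay.

The three share one core and differ in the ester group hanging from it. Compound 2 stands at the weak end of the numbers shown: its value is a limit, not a number, and the limit of > 15000 nM in this assay, at which 1 of the 3 values shown sits, describes where it sits. Compound 3, with its long chain, shows the lowest value of the three, and compound 1 lies between.

Compound 4 `C/C=C1/[C@H](O[C@@H]2O[C@H](CO)[C@@H](O)[C@H](O)[C@H]2O)OC=C(C(=O)OC)[C@H]1CC(=O)OCc1ccc2c(c1)OCCO2` is built from compound 2 by one change: 2,3-dihydro-1,4-benzodioxin-6-yl in place of 3,4-dimethoxybenzyl on a saturated chain carbon bound to an oxygen next to a carbonyl group. Both compound 2 and compound 4 carry a ring-bearing ester group of similar size, and compound 2 sits at the limit. Among the measured compounds shown here, no measured step of this kind exists to calibrate the change, so no shift beyond the scatter is expected; the result for compound 4 is estimated to remain near the limit, with the step from compound 2 expected to be a step that the limit leaves unreadable from compound 2 to compound 4. Compound 4 is expected to give about 20000 nM, in a range from 7000 nM to 60000 nM.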

Compound 4, half-maximal inhibitory concentration: > 15000 nM
Compound 4 was reported as a limit; the forecaster's own chance of this, stated with the estimate: 60%; the middle value lies beyond the limit too.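

Compound 2 and compound 4 both end at a limit of the assay rather than a number, so no step between them can be read: the limit of > 15000 nM in this assay, at which 2 of the 4 values shown sit.

The compounds shown leave open how far either lies past that limit, and whether exchanging 3,4-dimethoxybenzyl for 2,3-dihydro-1,4-benzodioxin-6-yl changes activity at all.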